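The source may hold more compounds than are shown below. What is called first, only, known or untested is meant among the compounds shown, and "the series" means these compounds.

Compound 1 `COc1cc(C(=O)c2sc(-c3ccc(I)cc3)cc2N)cc(OC)c1OC`: 420 nM
Compound 2 `COc1cc(C(=O)c2sc(-c3ccc(C)cc3)cc2N)cc(OC)c1OC`: 16 nM
Compound 3 `COc1cc(C(=O)c2sc(-c3ccc(C(F)(F)F)cc3)cc2N)cc(OC)c1OC`: not yet measured

Among the compounds with values here, in a functional assay on FM3A cells (Mus musculus) for antiproliferative activity (on this read-out lower numbers stand for stronger inhibition and higher numbers for weaker inhibition), compound 2 gives 16 nM, the lower of the two numbers so far, and compound 1 gives 420 nM. The change under review is trifluoromethyl in place of methyl on an aromatic carbon, para to a large group. Within the data shown here, only one measured step bears on this carbon, a 26-fold lower number from compound 1 to compound 2 (1.42 log units; beyond the scatter), with methyl in place of iodo. A single step sets no trend, but it shows that a swap at this carbon can move the number strongly. In this assay a move away from methyl is therefore expected to raise the number, by less than that step. The expected step is a 5.6-fold higher number from compound 2 to compound 3 (0.75 log units; beyond the scatter). For compound 3 the estimated value is 90 nM, with an expected range of 22 nM to 380 nM.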

Compound 3, half-maximal inhibitory concentration: 540 nM
Compound 3: middle estimate off by 6.0-fold (0.78 log units), on the low side; the measured number lies above the stated range.
By their numbers in this assay, from the lowest: compound 2; then compounds 1 and 3 (each within the scatter of the next).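

In this assay, the change from 4-methylphenyl to 4-(trifluoromethyl)phenyl gives a 34-fold higher number from compound 2 to compound 3 (1.53 log units; beyond the scatter), so a second replacement at this carbon also moves the number strongly, and this time away from methyl. Trifluoromethyl and iodo are not separated at this carbon, with a 1.3-fold higher number from compound 1 to compound 3 (0.11 log units; within the scatter), which leaves compound 2 with the lowest number of the three and its methyl group as the one substituent so far that gives a low number here. Nothing on hand accounts for the gap between methyl and the other two groups. As far as these compounds go, whether the low number is particular to methyl or extends to other small groups stays open. Ethyl, methoxy, chlorine or plain hydrogen on this carbon, with the rest of the core unchanged, would settle how narrow that preference is.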